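The compounds below may be only part of what the source reports. "The series", "measured", "known", "first", "only" and "open" are said of these compounds alone.

Measured so far in an assay on CHO cells for antagonist activity at transient receptor potential cation channel subfamily V member 1 (Homo sapiens), read by FLIPR; a lower number here means a stronger inhibitor, a higher number a weaker inhibitor:
compound 1 `CC(C(=O)NCc1ccc(C(F)(F)F)cc1OCc1ccccc1)c1ccc(NS(C)(=O)=O)c(F)c1` gives 0.9 nM
compound 2 `CC(C(=O)NCc1ccc(C(F)(F)F)cc1OCc1ccc(F)cc1)c1ccc(NS(C)(=O)=O)c(F)c1` gives 0.5 nM

Going by the values given here, compound 2 has the lowest of the two numbers, but its only neighbour, compound 1, sits within the scatter of it: a 1.8-fold lower number from compound 1 to compound 2 (0.26 log units; within the scatter). So the two measured compounds cannot be told apart in this assay.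

Compound 3 `CC(C(=O)NCc1ccc(C(F)(F)F)cc1SCc1ccccc1)c1ccc(NS(C)(=O)=O)c(F)c1` has not been measured. Its change from compound 2 is benzylsulfanyl in place of (4-fluorobenzyl)oxy on an aromatic carbon. This is two alterations in one: the fluorine on the outer ring is gone, and the oxygen linking that ring to the core is replaced by sulfur. Only the first alteration has a measured counterpart, the step from compound 1 to compound 2 read backwards, which stayed within the scatter. Among the compounds with values here, the oxygen-to-sulfur swap has no counterpart among the measured compounds, so nothing here says which way it pulls. The expectation for compound 3 is therefore a number close to that of compound 2, with a wide range to cover the unknown swap: a 3.0-fold higher number from compound 2 to compound 3 (0.48 log units; beyond the scatter). Compound 3 is estimated at 1.5 nM, between 0.4 nM and 6 nM.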

Compound 3, inhibition constant: 0.5 nM
Beside the measured number, compound 3's estimate is 3.0-fold (0.48 log units) above it; the measured number falls inside the stated range.
By their numbers in this assay, from the lowest: compounds 2, 3 and 1 (each within the scatter of the next).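

The cleanest view of the linking atom comes from benzylsulfanyl in place of benzyloxy, on the aromatic carbon ortho to a large group and meta to a trifluoromethyl group: in this assay this swap gives a 1.8-fold lower number from compound 1 to compound 3 (0.26 log units; within the scatter) and so leaves a sulfur link and an oxygen link indistinguishable at this position. Going by these compounds alone, the double change, with the sulfur link arriving and the fluorine on the outer ring leaving, gives no change at the digits printed from compound 2 to compound 3 (within the scatter) and shows that the two alterations together also produce no step that can be detected in this assay. Nothing measured on these compounds offers an explanation for why the two links read alike.

All three compounds carry a benzyl group linked through oxygen or sulfur, and this position has not yet shown a single step beyond the scatter, so how far it tolerates change remains unknown. An amine, a carboxylic acid or a longer chain such as phenethyloxy could test that, and a fluorine on the outer ring of the benzylsulfanyl group would show whether it reads the same there as on benzyloxy.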